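Chloro for Nitro on a Sulfonyl: Does Inactivity Persist?

The compounds below may be only part of what the source reports. "The series", "measured", "known", "first", "only" and "open" are said of these compounds alone.

The study concerns four acrylamides built on a common thiadiazole-bearing core and tested in a functional assay on RS4-11 cells (Homo sapiens) for inhibition, read by CCK-8 assay, with a stated time of 48 h, tested at 20 uM; a higher number here means more inhibition of growth at the concentration tested, a lower number less inhibition of growth. Compound 1 `N#C/C(=C\c1ccccc1OS(=O)(=O)c1ccccc1[N+](=O)[O-])C(=O)Nc1nnc(Cc2ccccc2)s1` gives 71%. Compound 2 `N#C/C(=C\c1ccccc1OS(=O)(=O)c1ccc(Cl)cc1)C(=O)Nc1nnc(Cc2ccccc2)s1` differs from compound 1 by 4-chlorophenyl in place of 2-nitrophenyl on a sulfonyl sulfur; in this assay compound 2 gives 73%. The step of a number 2 percentage points higher from compound 1 to compound 2 (within the scatter) is small and within the scatter, so the two values cannot be ordered.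

Compound 3 `Cc1ccc(Cc2nnc(NC(=O)/C(C#N)=C/c3ccccc3OS(=O)(=O)c3ccccc3[N+](=O)[O-])s2)cc1` differs from compound 1 by methyl in place of hydrogen on an aromatic carbon. In this assay compound 3 was reported as "not active" (no number reported), and no number was given for it. Compound 4 `Cc1ccc(Cc2nnc(NC(=O)/C(C#N)=C/c3ccccc3OS(=O)(=O)c3ccc(Cl)cc3)s2)cc1`, not yet measured, differs from compound 3 by 4-chlorophenyl in place of 2-nitrophenyl on a sulfonyl sulfur. This is the same change that separates compound 1 from compound 2: the group that leaves, the group that enters and the place on the sulfonyl sulfur are described in identical words in both pairs.

For the step from compound 3 to compound 4 a similarly small step is expected, because the step of a number 2 percentage points higher from compound 1 to compound 2 (within the scatter) lay within the scatter. Since compound 3 was inactive, compound 4 is therefore expected to show little inhibition as well, with the chance that it too is reported only as not active. The estimate for compound 4 is 15%, between 0% and 45%, resting on one measured pair only.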

Compound 4, percent growth inhibition at one concentration: 72%
Compound 4: middle estimate off by 57 percentage points, on the low side; the whole stated range lies below it.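

With 4-chlorophenyl on the sulfonyl sulfur, methyl in place of hydrogen on an aromatic carbon gives a number 1 percentage points lower from compound 2 to compound 4 (within the scatter), so compound 4 stands level with compound 2 and the methyl does not by itself go with a loss of inhibition in this series. The exchange of 2-nitrophenyl for 4-chlorophenyl therefore did not carry over from one core to the other: it made no readable difference on the core of compound 1, whereas in this assay on the methyl-bearing core it separates compound 3, reported as "not active" (no number reported), from compound 4 at 72% in the same test. The size of that second exchange cannot be read, as compound 3 has no number, and the single pair on each core shows only that the result of such an exchange on one core need not hold on the other, while nothing shown accounts for the difference between the cores.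

Left open is how a carboxylic acid or an amine in place of the methyl on the aromatic carbon would read in this test. Also open, from the compounds shown here alone, is whether the reading of compound 3 is tied to 2-nitrophenyl alone, or would recur with another group on the sulfonyl sulfur, such as 2-chlorophenyl, on the same core.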